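The compounds below may be only part of what the source reports. "The series", "measured", "known", "first", "only" and "open" are said of these compounds alone.

Compound 2 `COc1cc(Cl)cc(-c2nn(-c3cccc(NC(=O)Nc4ccc(Cl)c(Cl)c4)c3)cc2-c2ccncc2)c1` stands at the higher of the two numbers recorded so far: in a functional assay on NCI-H460 cells (Homo sapiens) for inhibition, read by sulforhodamine B assay, with a stated time of 48 h, tested at 0.1 uM (on this read-out higher numbers stand for a weaker effect at the one concentration tested and lower numbers for a stronger effect), compound 2 gives 100%. Its nearest neighbour is compound 1 `O=C(Nc1cccc(-n2cc(-c3ccncc3)c(-c3cc(O)cc(Cl)c3)n2)c1)Nc1ccc(Cl)c(Cl)c1`, which in this assay gives 97%; the step of a number 3 percentage points higher from compound 1 to compound 2 (within the scatter) lies within the scatter, so the two compounds cannot be told apart on this read-out. Compound 3 `COc1cc(Cl)cc(-c2nn(-c3cccc(NC(=O)c4cccc(C(F)(F)F)c4)c3)cc2-c2ccncc2)c1` differs from compound 2 in one place: 3-(trifluoromethyl)phenyl in place of (3,4-dichlorophenyl)amino on a carbonyl carbon. Going by the values given here, the only measured step, a number 3 percentage points higher from compound 1 to compound 2 (within the scatter), concerns a methyl in place of hydrogen on an oxygen on an aromatic ring and says nothing about exchanging the (3,4-dichlorophenyl)amino group on the carbonyl carbon for 3-(trifluoromethyl)phenyl. No measured comparison therefore bears on this change, and the expectation for compound 3 rests only on both measured compounds sitting near the top of the read-out in this assay. The step of a number 5 percentage points lower from compound 2 to compound 3 (within the scatter) is expected to be none beyond the scatter, with the range widened for want of any guiding comparison. Compound 3 is estimated to give 95% in this assay, within a range from 72% to 106%.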

Compound 3, a percentage reported as activity, at one concentration (the size of the read-out at that concentration, not a potency): 99%
Beside the measured number, compound 3's estimate is 4 percentage points below it, within the range that was stated.
By their numbers in this assay, from the lowest: compounds 1, 3 and 2 (each within the scatter of the next).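

In this assay, going by these compounds alone, the carbonyl carbon gives the first measured comparison at this position: 3-(trifluoromethyl)phenyl in place of (3,4-dichlorophenyl)amino gives a number 1 percentage points lower from compound 2 to compound 3 (within the scatter), so the two compounds cannot be told apart on this read-out. The change removes the hydrogen-bond donor and both chlorine atoms of the leaving group and brings in three fluorine atoms, yet compound 3 at 99% stays at the weak-effect end of the read-out with compound 2, so this exchange shows no effect that can be resolved at the one concentration tested. The data offer no measured basis for explaining this result.

Because all the numbers shown lie at that same end of the read-out, the compounds leave open whether any group on this carbonyl carbon could give a stronger effect, such as a dimethylamino group, a carboxylic acid or a longer alkyl chain. They also leave open how compound 2 and compound 3 would compare at other concentrations, since a reading at one concentration is not a potency.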